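The compounds below may be only part of what the source reports. "The series", "measured", "known", "first", "only" and "open" are said of these compounds alone.

Compound 1 `O=C(CN1CCCCC1)Nc1ccc2ncnc(Nc3ccc(Cl)cc3)c2c1` and compound 2 `O=C(CN1CCCCC1)Nc1ccc2ncnc(Nc3cccc(Br)c3)c2c1` share one core and differ only in the aryl group on a nitrogen on an aromatic ring. In a functional assay on HepG2 cells (Homo sapiens) for antiproliferative activity, read by MTT assay, with a stated time of 48 h (on this read-out higher numbers stand for weaker inhibition and lower numbers for stronger inhibition), compound 1 gives 16000 nM, and in this assay compound 2 gives 16000 nM. The step of no change at the digits printed from compound 1 to compound 2 (within the scatter) shows that a move of the halogen-bearing phenyl group left the read-out where it was. Among the compounds with values here, compound 2 therefore stands level with compound 1, its only measured neighbour, and neither can be called more or less active than the other.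

Compound 3 `O=C(CN1CCCCC1)Nc1ccc2ncnc(Nc3ccc(Br)cc3)c2c1` has the same atoms as compound 2, joined differently: 4-bromophenyl in place of 3-bromophenyl on a nitrogen on an aromatic ring. Within the data shown here, the only measured step that bears on this change, no change at the digits printed from compound 1 to compound 2 (within the scatter), was flat, so a further rearrangement of the same group is expected to stay flat as well. The step from compound 2 to compound 3 is expected to read no change at the digits printed from compound 2 to compound 3 (within the scatter), none beyond the scatter. Compound 3 is thus estimated at 16000 nM, within a range of 8000 nM to 32000 nM.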

Compound 3, half-maximal inhibitory concentration: > 100000 nM
Compound 3: only a limit was reported (the forecaster's own chance of this, stated with the estimate: 10%); at least 6.2-fold (0.79 log units) between middle value and limit.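

In this assay, putting 4-bromophenyl in place of 3-bromophenyl on a nitrogen on an aromatic ring, with the atoms unchanged, gives an at least 6.2-fold higher number from compound 2 to compound 3 (0.79 log units; beyond the scatter), so the place of the bromine on this phenyl group matters, which the flat earlier step did not reveal. Bromo in place of chloro on an aromatic carbon gives an at least 6.2-fold higher number from compound 1 to compound 3 (0.79 log units; beyond the scatter), so the halogen itself also counts here, even though 4-chlorophenyl and 3-bromophenyl read level. The figure for compound 3 is a limit and not a number, so both steps give only a minimum size: the limit of > 100000 nM in this assay, at which 1 of the 3 values shown sits.

As far as these compounds go, how far compound 3 really lies from the other two stays open. So does what 3-chlorophenyl or 4-fluorophenyl would give on the same nitrogen, and with it whether halogen and place act independently or only together.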